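Methanesulfonamide in place of a methylpyrazole on the shared core

This account rests on a few compounds, and the source may have more. Where it says the series, first, only, none or still open, it means among the compounds named here.

Measured compounds:
compound 1 `c1cc(-c2ccn[nH]2)c2c(c1)C(c1ncc[nH]1)CC2` 83%
compound 2 `Cn1ccc(-c2cccc3c2CCC3c2ncc[nH]2)n1` 19%
compound 3 `CS(=O)(=O)Nc1c(Cl)ccc2c1CCCC2c1ncc[nH]1` 61%

In a functional assay on CHO cells for agonist activity at Alpha-1A adrenergic receptor (Homo sapiens), read by FLIPR and calcium flux (a higher number here means a larger maximal response, a lower number a smaller maximal response), compound 2 gives the lowest of the three numbers. Its nearest neighbour is compound 3 with 61%, and the furthest is compound 1 with 83%; both gaps are beyond the scatter.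

Compound 4 `CS(=O)(=O)Nc1cccc2c1CCC2c1ncc[nH]1` has not been measured. It differs from compound 2 in one place: methanesulfonamido in place of 1-methyl-1H-pyrazol-3-yl on an aromatic carbon.

For the measured compounds named here, no measured step shares this exact change. Going by the values given here, the only step on record, a number 64 percentage points lower from compound 1 to compound 2 (beyond the scatter), shows that the 1-methyl-1H-pyrazol-3-yl group of compound 2 goes with a much smaller maximal response than the 1H-pyrazol-5-yl group of compound 1. Compound 3 carries the same methanesulfonamido group that enters in compound 4, on a different core and with a chloro substituent, and its value stands well above that of compound 2.

Compound 4 is therefore expected to gain clearly, with a number 41 percentage points higher from compound 2 to compound 4 (beyond the scatter) estimated as a large step upward. The estimate for compound 4 is 60%, expected to fall between 35% and 85%.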

Compound 4, largest response reached (Emax), in percent of the reference or control that the assay uses: 87%
Estimate against measurement, compound 4: 27 percentage points below, and the stated range ends below it.
By their numbers in this assay, from the lowest: compound 2; then compound 3; then compounds 1 and 4 (each within the scatter of the next).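

On the shared core, at this aromatic carbon ortho to a fused ring, putting methanesulfonamido in place of 1-methyl-1H-pyrazol-3-yl gives a number 68 percentage points higher from compound 2 to compound 4 (beyond the scatter) in this assay, so a group with no ring can carry a large maximal response here. Set against the unmethylated heterocycle, the same group gives a number 4 percentage points higher from compound 1 to compound 4 (within the scatter), which leaves 1H-pyrazol-5-yl and methanesulfonamido indistinguishable in this read-out, and of the compounds on this core only compound 2 stands apart. No measurement at hand accounts for the size of these steps.

Going by these compounds, it remains open whether the maximal response survives if the amide hydrogen of the methanesulfonamido group is replaced by a methyl group. On these data alone, how an acetamide, a simple amine or a carboxylic acid would behave on this aromatic carbon also remains open.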